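A few compounds are considered here, and "the series" means these few. Any claim that something is new, unique, unknown or untested is made for them only; others in the source may bear on it.

Four compounds share one core and differ only in the group carried on it. Compound 1 `Cn1c(=O)c2[nH]c(SCC(=O)c3ccc(Cl)cc3)nc2n(C)c1=O` bears a 4-chlorophenyl group; in a functional assay on HT-29 cells (Homo sapiens) for inhibition, read by MTT assay, with a stated time of 48 h (on this read-out higher numbers stand for weaker inhibition and lower numbers for stronger inhibition), compound 1 gives 9900 nM. Compound 2 `Cn1c(=O)c2[nH]c(SCC(=O)c3ccc(Br)cc3)nc2n(C)c1=O` differs from it by bromo in place of chloro on an aromatic carbon, and in this assay compound 2 gives 6500 nM, so that a 1.5-fold lower number from compound 1 to compound 2 (0.18 log units; within the scatter). Compound 3 `Cn1c(=O)c2[nH]c(SC/C(=N/O)c3ccc(Cl)cc3)nc2n(C)c1=O` rests on a different core; how that core differs from the core of compound 1 is not broken down here. In this assay compound 3 gives 1200 nM, the lowest of the three measured numbers and beyond the scatter from both compound 1 and compound 2. Compound 4 `Cn1c(=O)c2[nH]c(SC/C(=N/O)c3ccc(Br)cc3)nc2n(C)c1=O` differs from compound 3 by bromo in place of chloro on an aromatic carbon, the same change that separates compound 1 from compound 2. Because that earlier step was a 1.5-fold lower number from compound 1 to compound 2 (0.18 log units; within the scatter), the step from compound 3 to compound 4 is expected to be of similar size, a 1.3-fold lower number from compound 3 to compound 4 (0.12 log units; within the scatter), an expectation resting on a single precedent. Compound 4 is therefore estimated to give about 900 nM in this assay, with a likely range from 400 nM to 2000 nM.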

Compound 4, half-maximal inhibitory concentration: 1700 nM
Compound 4: the middle estimate sits 1.9-fold (0.28 log units) below what was measured; the range from low to high includes it.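

Replacing chloro with bromo on the core of compound 3 gives, in this assay, a 1.4-fold higher number from compound 3 to compound 4 (0.15 log units; within the scatter), so this step is no larger than the differences seen between repeated measurements. Set beside the same change on the core of compound 1, the result is consistent across the two cores: the same change on two cores in this assay, a 1.5-fold lower number (0.18 log units; within the scatter) from compound 1 to compound 2 and a 1.4-fold higher number (0.15 log units; within the scatter) from compound 3 to compound 4, 2.2-fold (0.33 log units) apart, within the scatter of two such steps. This shows that, for these two pairs, the change makes no measurable difference on either core, and the opposite directions of the two steps should not be read as a real reversal, but two pairs cannot show that the same would hold on any other core or in any other assay.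

The compounds shown carry only chloro or bromo on the aromatic ring, so they leave open whether a different group in that place, such as fluoro, methoxy, an amine or a carboxylic acid, would give a step beyond the scatter. Going by these compounds, whether any such group would behave alike on both cores also remains open.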